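This account rests on a few compounds, and the source may have more. Where it says the series, first, only, none or still open, it means among the compounds named here.

Three related compounds have been measured in a functional assay on Caco-2 cells (Homo sapiens) for antiproliferative activity, read by MTT assay, with a stated time of 48 h (on this read-out higher numbers stand for weaker inhibition and lower numbers for stronger inhibition), and their values sit close together. There compound 1 (`C=C(C(=O)O)[C@@H]1CC[C@]2(C)C(=C(C)C(=O)[C@@H](O)[C@H]2O)C1`) gives 66000 nM and compound 2 (`C=C(C(=O)O)[C@@H]1CC[C@]2(C)C(=C(C)C(=O)C[C@H]2O)C1`) gives 75000 nM while compound 3 (`C=C(C(=O)O)[C@@H]1CC[C@@]2(C)C=C(O)C(=O)C(C)=C2C1`) gives 46000 nM as its value, which lies within the scatter of both others. Compound 4 (`C=C(C(=O)O)[C@@H]1CC[C@@]2(C)C=CC(=O)C(C)=C2C1`) differs from compound 3 by one change, hydrogen in place of hydroxy on a double-bonded ring carbon. Going by the values given here, only one measured step bears on it, and only loosely: hydrogen in place of hydroxy on a saturated ring carbon gave a 1.1-fold higher number from compound 1 to compound 2 (0.06 log units; within the scatter) and stays within the scatter. Among the compounds with values here, that swap sits on a different kind of ring carbon, and the data hold no measured example of the change on a double-bonded ring carbon, so it is a guide and not a match. With a single step of that size and three values so close, no shift beyond the scatter is expected in this assay for this change, and no direction is favoured. The expected step is a 1.1-fold higher number from compound 3 to compound 4 (0.04 log units; within the scatter) and it remains an estimate. For compound 4 the estimated value is 50000 nM with an expected range from 22000 nM to 105000 nM as the likely span.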

Compound 4, half-maximal inhibitory concentration: 66000 nM
For compound 4 the middle estimate is 1.3-fold (0.12 log units) below the measured one; low and high end bracket the measured number.
By their numbers in this assay, from the lowest: compounds 3, 1, 4 and 2 (each within the scatter of the next).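

Replacing the hydroxy with hydrogen on this double-bonded ring carbon gives, in this assay, a 1.4-fold higher number from compound 3 to compound 4 (0.16 log units; within the scatter), so the hydroxy can be lost from this position of the shared core with no shift beyond the scatter. Going by these compounds alone, this is the first measured case of the swap on a double-bonded ring carbon, and it agrees with the earlier case on a saturated ring carbon, a 1.1-fold higher number from compound 1 to compound 2 (0.06 log units; within the scatter): in both pairs, the hydroxy and hydrogen forms cannot be told apart in this assay. No supporting data are available to account for this outcome.

With only hydroxy and hydrogen shown on this double-bonded ring carbon, it remains open whether an amine, a methoxy group or a longer chain there would also stay within the scatter of compound 3 or would move the number beyond it. Also open, on these data alone, is whether the swap at this position would remain as small in any read-out other than this assay.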